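The source may report more compounds than this note shows. Statements on the series, on what has been measured and on what is new or still open speak of the compounds shown alone.

Measured so far in an assay on HEK293 cells for agonist activity at Toll-like receptor 8 (Homo sapiens), read by a luciferase reporter, with a stated time of 6 h; on this read-out lower numbers stand for an effect already at smaller amounts and higher numbers for an effect only at larger amounts of compound:
compound 1 `CCCCNc1nc(N)nc2ccn(Cc3ccccc3)c12`: > 25 uM
compound 2 `CCCCNc1nc(N)nc2ccn(Cc3nccs3)c12`: 2.27 uM

The value for compound 1 is a limit of this assay, not a number; this is the limit of > 25 uM in this assay, at which 1 of the 2 values shown sits. For the measured compounds named here, compound 2 is therefore the only compound with a number in this assay, and it stands alone at 2.27 uM.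

Going by the values given here, the one measured step, an at least 11-fold lower number from compound 1 to compound 2 (1.04 log units; beyond the scatter), is large and beyond the scatter.

Compound 3 `CCCCNc1nc(N)nc2ccn(Cc3cccc(C)n3)c12` is not yet measured. It differs from compound 2 by 6-methylpyridin-2-yl in place of 1,3-thiazol-2-yl on a saturated chain carbon bound to an aromatic nitrogen. Among the compounds with values here, no measured step covers this particular change; the step from compound 1 to compound 2 concerns a different exchange at the same place and is only indirect guidance, showing that the group at this position can move the number strongly. With one ring nitrogen acceptor kept, compound 3 is expected to land near compound 2, with a step of a 1.1-fold higher number from compound 2 to compound 3 (0.04 log units; within the scatter), so compound 3 is estimated at 2.5 uM (range 0.5 uM to 12 uM).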

Compound 3, minimum effective concentration: > 25 uM
Compound 3 was reported as a limit; the forecaster's own chance of this, stated with the estimate: 20%; at least 10-fold (1.00 log units) between middle value and limit.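

In this assay, a ring nitrogen in the group on a saturated chain carbon bound to an aromatic nitrogen is not enough to keep the effect: 6-methylpyridin-2-yl in place of 1,3-thiazol-2-yl gives an at least 11-fold higher number from compound 2 to compound 3 (1.04 log units; beyond the scatter). Among the groups shown at this place, only 1,3-thiazol-2-yl gives a number rather than a limit. Compound 1 and compound 3 are both reported as limits, and the step between them cannot be read: the limit of > 25 uM in this assay, at which 2 of the 3 values shown sit.

From the compounds shown here alone, it remains open whether the loss in compound 3 belongs to the methyl group or to the six-membered ring; an unsubstituted pyridine ring at this place would separate the two. Going by these compounds, it also remains open whether the effect of compound 2 depends on the sulfur, which an oxazole ring at this place would address.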